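The source may hold more compounds than are shown below. What is called first, only, known or untested is meant among the compounds shown, and "the series" means these compounds.

In an ADME assay for permeability, using PAMPA, with a stated time of 30 min, at pH 7.4 (on this read-out higher numbers stand for higher permeability and lower numbers for lower permeability), the readings so far are few. Compound 1 (`COc1ccc(-c2c(-c3ccc(OC)cc3)n(Cc3ccccc3)c3ncn([C@H]4CC[C@H](OC)CC4)c(=N)c23)cc1`) gives > 1000 10^-6 cm/s as a limit of the assay and not a number. Compound 3 (`N=c1c2c(-c3ccccc3)c(-c3ccccc3)n(Cc3ccccc3)c2ncn1CCCN1CCN(c2ccccc2)CC1`) likewise gives > 1000 10^-6 cm/s as a limit. For the measured compounds named here, compound 2 (`N=c1c2c(-c3ccccc3)cn(Cc3ccccc3)c2ncn1CCO`) reads 1270 10^-6 cm/s as the only actual number of the three. Compound 4 (`N=c1c2c(-c3ccccc3)cn(Cc3ccccc3)c2ncn1C1CCOCC1`) carries oxan-4-yl in place of 2-hydroxyethyl on an aromatic nitrogen. No measured step sizes this change, so no shift beyond the usual scatter in this assay is expected in either direction. The estimated move a 1.1-fold higher number from compound 2 to compound 4 (0.04 log units; within the scatter) stays small. For compound 4 the expected value is 1400 10^-6 cm/s with an estimated range from 750 10^-6 cm/s to 2600 10^-6 cm/s on this read-out.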

Compound 4, apparent permeability: 1730 10^-6 cm/s
Estimate against measurement, compound 4: 1.2-fold (0.09 log units) below; measured number inside the range.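

In this assay, for the compounds shown here, oxan-4-yl in place of 2-hydroxyethyl on the aromatic nitrogen gives the first step that can be sized at this position: a 1.4-fold higher number from compound 2 to compound 4 (0.13 log units; within the scatter). For this one pair, exchanging a group with a hydrogen-bond donor for a six-membered non-aromatic ring with none leaves the read-out within the scatter. Compound 1 and compound 3 add no step, and the series has little room for numbers: the limit of > 1000 10^-6 cm/s in this assay, at which 2 of the 4 values shown sit.

Still open, on these data alone, is whether a carboxylic acid or a sulfonamide on this nitrogen would give a step beyond the scatter. As far as these compounds go, whether the same exchange holds on the core of compound 1 is also open.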